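A few compounds are considered here, and "the series" means these few. Any claim that something is new, unique, unknown or untested is made for them only; others in the source may bear on it.

In a functional assay on A2780 cells (Homo sapiens) for cytotoxicity, read by MTT assay, with a stated time of 72 h (on this read-out lower numbers stand for stronger inhibition and higher numbers for weaker inhibition), compound 1 (`Nc1ccccc1NC(=O)CCCCCN(CC(=O)NCc1ccccc1)C(=O)c1cccc2ccccc12`) gives 22800 nM and compound 2 (`Cc1cc(C)cc(C(=O)N(CCCCCC(=O)Nc2ccccc2N)CC(=O)NCc2ccccc2)c1`) gives 20900 nM. These two numbers lie within the scatter of each other, so compound 2 stands level with compound 1 on the data so far. Compound 3 (`Cc1cc(C)cc(CNC(=O)CN(CCCCCC(=O)Nc2ccccc2N)C(=O)c2cc(C)cc(C)c2)c1`) has not yet been measured. Its difference from compound 2 is 3,5-dimethylphenyl in place of phenyl on a saturated chain carbon bound to an amide-type nitrogen. In other words, benzylcarbamoyl becomes (3,5-dimethylbenzyl)carbamoyl. Going by the values given here, only one measured step offers any guidance, and it does so indirectly: a 1.1-fold lower number from compound 1 to compound 2 (0.04 log units; within the scatter), with 3,5-dimethylphenyl in place of naphthalen-1-yl on a carbonyl carbon. Among the compounds with values here, that change lies at a different place in the molecule, and no measured step touches the benzyl group. Within the data shown here, the one step available stayed within the scatter, so a change beyond the scatter is not expected in this assay, and the data give no direction. The expected step is a 1.1-fold lower number from compound 2 to compound 3 (0.04 log units; within the scatter). The estimate for compound 3 is 19000 nM, with an expected range from 8000 nM to 42000 nM.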

Compound 3, half-maximal inhibitory concentration: 5100 nM
Beside the measured number, compound 3's estimate is 3.7-fold (0.57 log units) above it, outside the stated range (below it).
By their numbers in this assay, from the lowest: compound 3; then compounds 2 and 1 (each within the scatter of the next).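

In this assay, the benzylcarbamoyl end of the molecule proves to be a place where the read-out responds, with a 4.1-fold lower number from compound 2 to compound 3 (0.61 log units; beyond the scatter). Going by these compounds alone, the only earlier step, at the carbonyl carbon, stayed within the scatter, with a 1.1-fold lower number from compound 1 to compound 2 (0.04 log units; within the scatter), so compound 3 gives the first sign that the series can move at all in this assay, and it does so at a saturated chain carbon bound to an amide-type nitrogen. The change is small on paper, since phenyl and 3,5-dimethylphenyl are both a single six-membered aromatic ring of carbon only with no hydrogen-bond donors or acceptors, and nothing available here bears on why this swap lowers the number.

The compounds shown leave open whether both methyl groups are needed, and whether a single methyl, a chlorine or a methoxy group on the same ring, or a pyridine ring in its place, would give a similar step. They also leave open whether the step would hold with naphthalen-1-yl on the carbonyl carbon, as in compound 1, instead of 3,5-dimethylphenyl.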